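A few compounds are considered here, and "the series" means these few. Any claim that something is new, unique, unknown or untested is made for them only; others in the source may bear on it.

Series notes on the cytotoxicity set. Compound 1 `C/C(=C/CC/C(C)=C/CC/C(C)=C/C(=O)C/C(C)=C/Cc1cc(O)cc(C)c1O)CO` and compound 2 `C/C(=C/CC/C(C)=C/CC/C(C)=C\C(=O)C/C(C)=C/Cc1cc(O)cc(C)c1O)CO` carry the shared core with a 3-(hydroxymethyl)but-2-en-1-yl group, while compound 3 `C/C(=C\C(=O)C/C(C)=C/Cc1cc(O)cc(C)c1O)CC/C=C(\C)Cc1cc(C)co1` carries a 4-methylfuran-2-yl group in its place. In a functional assay on MCF7 cells (Homo sapiens) for cytotoxicity (on this read-out lower numbers stand for higher toxicity in this test and higher numbers for lower toxicity in this test), compound 1 reports only a limit, > 10 ug/mL. In this assay compound 2 likewise reports only a limit, > 10 ug/mL. In this assay, going by the values given here, compound 3 gives 3.7 ug/mL, the only actual number in the set. The replacement of the chain group by the furan group appears as an at least 2.7-fold lower number from compound 1 to compound 3 (0.43 log units; beyond the scatter). The geometric change within the first pair, a step that the two limits leave unreadable from compound 1 to compound 2, cannot be sized because the limit of > 10 ug/mL in this assay, at which 2 of the 3 values shown sit, and because of the fact that compounds 1 and 2 differ only in the configuration as drawn.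

Compound 4 `C/C(=C/C(=O)C/C(C)=C/Cc1cc(O)cc(C)c1O)CC/C=C(\C)Cc1cc(C)co1` differs from compound 3 only in drawn configuration: the two compounds have the same atoms and bonds and differ only in configuration as drawn: 1 of 3 stereo elements differ; a double bond is drawn E in compound 3 and Z in compound 4. Among the compounds with values here, the only comparable step in the set, that between compound 1 and compound 2, is unreadable, so no direction can be drawn from it. For compound 4 a step within the scatter is therefore expected, a 1.1-fold higher number from compound 3 to compound 4 (0.02 log units; within the scatter). Compound 4 is thus estimated at 3.9 ug/mL, with a range from 1.8 ug/mL to 9 ug/mL.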

Compound 4, concentration lethal to 50% of the cells: 3.6 ug/mL
Estimate against measurement, compound 4: 1.1-fold (0.03 log units) above; low and high end bracket the measured number.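

The change in drawn geometry now has its first readable step, a 1.0-fold lower number from compound 3 to compound 4 (0.01 log units; within the scatter), so in this assay this E to Z change on a double bond leaves the number unmoved beyond the scatter when the 4-methylfuran-2-yl group is present. The exchange of 3-(hydroxymethyl)but-2-en-1-yl for 4-methylfuran-2-yl also holds with the Z-drawn bond, an at least 2.7-fold lower number from compound 2 to compound 4 (0.44 log units; beyond the scatter). The lower number therefore follows this exchange with either drawn geometry: the same change on two cores in this assay, an at least 2.7-fold lower number (0.43 log units; beyond the scatter) from compound 1 to compound 3 and an at least 2.7-fold lower number (0.44 log units; beyond the scatter) from compound 2 to compound 4; the limit leaves it open whether they differ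

On these data alone, the full size of the exchange stays open, since each step starts from a limit: the limit of > 10 ug/mL in this assay, at which 2 of the 4 values shown sit. Whether the geometry change is equally silent with the 3-(hydroxymethyl)but-2-en-1-yl group cannot be read, and how a carboxylic acid or a longer chain in place of 4-methylfuran-2-yl would read in this assay remains open.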